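Isopropyl to Difluoromethyl on an Oxygen on an Aromatic Ring

This account rests on a few compounds, and the source may have more. Where it says the series, first, only, none or still open, it means among the compounds named here.

Measured so far, in an ADME assay on microsomes from liver (Mus musculus) for metabolic stability; on this read-out lower numbers stand for slow clearance and higher numbers for fast clearance:
compound 1 `CCOc1cc([C@](O)(CCN(C)C)[C@@H](c2cc3cc(Br)ccc3nc2OC)c2cccc(OC)c2F)cc(OC)n1` gives 14 uL/min
compound 2 `COc1cc([C@](O)(CCN(C)C)[C@@H](c2cc3cc(Br)ccc3nc2OC)c2cccc(OC)c2F)cc(OC(C)C)n1` gives 6 uL/min
compound 3 `COc1cc([C@](O)(CCN(C)C)[C@@H](c2cc3cc(Br)ccc3nc2OC)c2ccnc(OC)c2OC)cc(OC(C)C)n1` gives 6.7 uL/min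

Among these three, compound 2 has the lowest number. Its nearest neighbour is compound 3, and that gap, a 1.1-fold higher number from compound 2 to compound 3 (0.05 log units; within the scatter), lies within the scatter, so the two cannot be ranked. The only clear gap is to compound 1: a 2.3-fold lower number from compound 1 to compound 2 (0.37 log units; beyond the scatter), a modest step produced by methyl in place of hydrogen on a saturated chain carbon bound to an oxygen on an aromatic ring and a saturated chain carbon.

Compound 4 `COc1cc([C@](O)(CCN(C)C)[C@@H](c2cc3cc(Br)ccc3nc2OC)c2cccc(OC)c2F)cc(OC(F)F)n1` differs from compound 2 in one place: difluoromethyl in place of isopropyl on an oxygen on an aromatic ring. This touches the same oxygen as the step from compound 1 to compound 2, so that step is the one that bears on it. It showed that a change at this oxygen can move the number by a modest amount. Within the data shown here, compound 4 gives up the isopropyl, and no measured compound carries difluoromethyl at this position, so the direction rests on one step only.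

The expectation is a small rise in this assay for compound 4, a 1.3-fold higher number from compound 2 to compound 4 (0.12 log units; within the scatter), likely within or just beyond the scatter. Compound 4 is therefore estimated at 8 uL/min, with a range from 4 uL/min to 16 uL/min.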

Compound 4, intrinsic clearance in a liver preparation (reported as CLH), per the amount of preparation that the assay uses: 6.4 uL/min
Compound 4: middle estimate off by 1.3-fold (0.10 log units), on the high side, within the range that was stated.
By their numbers in this assay, from the lowest: compounds 2, 4 and 3 (each within the scatter of the next); then compound 1.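

In this assay, the exchange of isopropoxy for difluoromethoxy gives a 1.1-fold higher number from compound 2 to compound 4 (0.03 log units; within the scatter), so on this read-out the two groups cannot be told apart, even though they share no atoms beyond a single carbon type and differ in what they carry. The low number is therefore not tied to isopropyl alone: the listing also gives a 2.2-fold lower number from compound 1 to compound 4 (0.34 log units; beyond the scatter), which sets the ethyl of compound 1 clearly apart from difluoromethyl, just as a 2.3-fold lower number from compound 1 to compound 2 (0.37 log units; beyond the scatter) sets it apart from isopropyl. Nothing available here explains why these groups on the same oxygen give the numbers they do.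

The compounds shown leave open whether trifluoromethyl, cyclopropyl or a longer chain on this oxygen would stay level with compound 2 and compound 4 or sit nearer compound 1. Among these compounds, they also leave open whether difluoromethyl would behave the same way with 2,3-dimethoxypyridin-4-yl in place of 2-fluoro-3-methoxyphenyl, the one other change seen in compound 3.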